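Pyridinyl ether variation on a benzimidazole-acid series

The source may hold more compounds than are shown below. What is called first, only, known or untested is meant among the compounds shown, and "the series" means these compounds.

Two compounds of the series have been run in a physicochemical assay for lipophilicity, read by LC-MS, in phosphate buffer, measured as octanol-water partition, with a stated time of 30 min, at pH 7.4, tested at 200 mM; on this read-out lower numbers stand for lower lipophilicity and higher numbers for higher lipophilicity. Compound 1 `Cn1c(COc2cccc(C(=O)O)c2)nc2cnc(Oc3ccc(Cl)c(F)c3)cc21` gives 1.4 in this assay. Compound 2 `Cn1c(COc2cccc(C(=O)O)c2)nc2ccc(Oc3ccc(Cl)cn3)cc21` gives 1.2 in this assay, and the gap between compound 2 and compound 1 falls within the usual scatter, so no order between the two can be read from these numbers.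

Compound 3 `Cc1cnc(Oc2ccc3nc(COc4cccc(C(=O)O)c4)n(C)c3c2)c(F)c1` has not been measured. Relative to compound 2 the change is 3-fluoro-5-methylpyridin-2-yl in place of 5-chloropyridin-2-yl on an oxygen on an aromatic ring. Going by the values given here, no step between measured compounds is available for this change, so its size has to be guessed from the structures alone: a chlorine leaves, a methyl and a fluorine enter, and these are expected to roughly offset one another, giving no step beyond the scatter in this assay.

The step from compound 2 to compound 3 is expected to be no change at the digits printed from compound 2 to compound 3 (within the scatter). Compound 3 is expected to give 1.2 in this assay, in a range from 0.8 to 1.6.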

Compound 3, distribution coefficient: 1.1
Estimate against measurement, compound 3: 0.10 log units above, and the stated range covers the measured number.
By their numbers in this assay, from the lowest: compounds 3, 2 and 1 (each within the scatter of the next).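

In this assay, 3-fluoro-5-methylpyridin-2-yl in place of 5-chloropyridin-2-yl on an oxygen on an aromatic ring gives a number 0.10 log units lower from compound 2 to compound 3 (within the scatter), the first step measured for a change at this position. The read-out thus shows no separable shift when the chlorine leaves and a methyl and a fluorine enter together. No measurement at hand offers an explanation for this step.

Only the combined exchange is shown, so the separate contributions of the fluorine and the methyl cannot be read. Also open, on these data alone, is whether an amine in place of the methyl on this pyridine would move the read-out beyond the scatter.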